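The source may report more compounds than this note shows. Statements on the series, on what has been measured and on what is new or still open speak of the compounds shown alone.

Measured so far in a physicochemical assay for lipophilicity, at pH 7.4 (a higher number here means a more lipophilic compound, a lower number a more polar compound), are these compounds:
- compound 1 `CCOC(=O)[C@@H](N)CCC(=O)NCCSC(=O)c1ccccc1` gives -0.37
- compound 2 `CCOC(=O)[C@@H](N)CCC(=O)NCCSC(=O)C(C)(C)C` gives -0.29
- compound 3 `CCCOC(=O)[C@@H](N)CCC(=O)NCCSC(C)=O` gives -1.21

Compound 3 stands lowest of the three in this assay, and its gaps up to compound 1 and compound 2 both lie beyond the scatter. The next compound, compound 4 `CCCCOC(=O)[C@@H](N)CCC(=O)NCCSC(C)=O`, has not yet been measured. It differs from compound 3 by one small change: methyl in place of hydrogen on a saturated chain carbon, three bonds along the chain from an oxygen next to a carbonyl group. This is methyl in place of hydrogen on a saturated chain carbon, three bonds along the chain from an oxygen next to a carbonyl group. Cut one bond further out, the same difference reads propyl to butyl.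

Among the measured compounds shown here, only one step between measured compounds is available: a number 0.08 log units higher from compound 1 to compound 2 (within the scatter). It is tert-butyl in place of phenyl on a carbonyl carbon, a different change in a different place, so it does not bear on this one. For the measured compounds named here, no measured step involves compound 3, which leaves the size of the new step resting on the structural change alone. That change adds a single carbon, with no hydrogen-bond donors or acceptors and no net charge. A moderate rise from compound 3 (-1.21) is therefore expected, probably just beyond the scatter. The expected change is a number 0.46 log units higher from compound 3 to compound 4 (beyond the scatter), and it is only an estimate. For compound 4 the estimated value is -0.75 (expected range -1.05 to -0.45).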

Compound 4, distribution coefficient: -0.88
Compound 4: middle estimate off by 0.13 log units, on the high side, and the stated range covers the measured number.
By their numbers in this assay, from the lowest: compound 3; then compound 4; then compounds 1 and 2 (each within the scatter of the next).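

Among the compounds shown here, replacing hydrogen with methyl on a saturated chain carbon, three bonds along the chain from an oxygen next to a carbonyl group, turns propyl into butyl and gives the first measured step at this position in this assay: a number 0.33 log units higher from compound 3 to compound 4 (beyond the scatter). For the compounds shown here, the earlier compounds offered no step at this place, so this pair is the first to put a size on a single added carbon here, and that size is modest, though it lies beyond the usual scatter. Nothing measured here explains why the step has this size.

A single step cannot show whether each further carbon would add a similar amount, so a longer chain such as pentyl or hexyl, or a branched one such as isobutyl, remains an open test of this position. From the compounds shown here alone, it also remains open how the number would respond to an amine or a carboxylic acid at the end of this chain, or whether the same added carbon would give a similar step with a benzoyl or pivaloyl group at the other end of the molecule.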